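Swapping the Aryl Group: Expected Cytotoxicity of Compound 3

The compounds below may be only part of what the source reports. "The series", "measured", "known", "first", "only" and "open" are said of these compounds alone.

Compound 1 `C=CC(=O)Nc1cc(Nc2ncc3ncn(-c4ccc(F)cc4)c3n2)c(OC)cc1N(C)CCN(C)C`: 12000 nM
Compound 2 `C=CC(=O)Nc1cc(Nc2ncc3ncn(-c4ccc(I)cc4)c3n2)c(OC)cc1N(C)CCN(C)C`: 9520 nM

Of the compounds shown here, two have been measured in an ADME assay on HT-29 cells (Homo sapiens) for cytotoxicity, read by MTT assay, with a stated time of 72 h; a higher number here means a weaker inhibitor, a lower number a stronger inhibitor. Compound 1 gives 12000 nM and compound 2 gives 9520 nM; the two numbers lie within the scatter of each other, so compound 2 stands level with compound 1 rather than apart from it. Going by the values given here, the single measured step, a 1.3-fold lower number from compound 1 to compound 2 (0.10 log units; within the scatter), exchanged one halogen for another on an aromatic carbon and barely moved the number.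

Compound 3 `C=CC(=O)Nc1cc(Nc2ncc3ncn(-c4ccc(Cl)cc4Cl)c3n2)c(OC)cc1N(C)CCN(C)C` differs from compound 2 in one place: 2,4-dichlorophenyl in place of 4-iodophenyl on an aromatic nitrogen. Among the compounds with values here, the only step that bears on this is the halogen exchange, and because a 1.3-fold lower number from compound 1 to compound 2 (0.10 log units; within the scatter) stayed within the scatter, no movement beyond the scatter is expected in this assay for a change that again swaps halogens on the same aryl group, now with a second chlorine. Compound 3 is therefore expected to give about 10000 nM, ranging from 4000 nM to 25000 nM. The expected step is a 1.1-fold higher number from compound 2 to compound 3 (0.02 log units; within the scatter).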

Compound 3, half-maximal inhibitory concentration: 20600 nM
The estimate for compound 3 lay 2.1-fold (0.31 log units) below the measured number; measured number inside the range.
By their numbers in this assay, from the lowest: compounds 2, 1 and 3 (each within the scatter of the next, the first and the last beyond it).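

In this assay, the aryl group on the aromatic nitrogen can move the number beyond the scatter: there is a 2.2-fold higher number from compound 2 to compound 3 (0.34 log units; beyond the scatter), whereas the earlier exchange of one halogen for another at this place did not. The reading depends on the comparison, however, as there is also a 1.7-fold higher number from compound 1 to compound 3 (0.23 log units; within the scatter), so 2,4-dichlorophenyl stands apart from 4-iodophenyl but not from 4-fluorophenyl. No measurement available here gives a cause for the step.

The second chlorine and the change of halogen arrive together, and a 4-chlorophenyl group would be needed to separate them. As far as these compounds go, how a 4-methoxyphenyl group, an aminophenyl group or a plain alkyl chain would read on the same aromatic nitrogen also remains open.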